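Ester variation on the sulfamoyl carbamate series

The compounds below may be only part of what the source reports. "The series", "measured", "known", "first", "only" and "open" are said of these compounds alone.

In an assay on liver for inhibition of sterol O-acyltransferase 1 (Rattus norvegicus), using microsomes (on this read-out lower numbers stand for stronger inhibition and higher numbers for weaker inhibition), compound 1 `CC(C)c1cccc(C(C)C)c1OS(=O)(=O)NC(=O)OC1CCCCC1` gives 38000 nM, the highest of the two numbers in hand. Compound 2 `CC(C)c1cccc(C(C)C)c1OS(=O)(=O)NC(=O)OC1[C@@H](C(C)C)CCC[C@H]1C(C)C` gives 3600 nM in this assay, a lower number, the gap lying beyond the scatter. Compound 3 `CC(C)c1cccc(C(C)C)c1OS(=O)(=O)NC(=O)Oc1ccc(F)cc1F` carries 2,4-difluorophenyl in place of cyclohexyl on an oxygen next to a carbonyl group. For the measured compounds named here, no measured pair shares this change, so the step is expected to be small, toward a lower number, and of a size near the edge of the scatter: a 1.9-fold lower number from compound 1 to compound 3 (0.28 log units; within the scatter). For compound 3 the estimate in this assay is 20000 nM, with a range from 5000 nM to 80000 nM.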

Compound 3, half-maximal inhibitory concentration: > 50000 nM
Compound 3 gave a limit, no number (the forecaster's own chance of this, stated with the estimate: 10%); middle value at least 2.5-fold (0.39 log units) from the limit.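

Compound 3 reads only as a limit of the assay, not as a number: the limit of > 50000 nM in this assay, at which 1 of the 3 values shown sits.

On an oxygen next to a carbonyl group, 2,4-difluorophenyl in place of cyclohexyl gives, in this assay, an at least 1.3-fold higher number from compound 1 to compound 3 (0.11 log units; that floor lies within the scatter). Going by these compounds, this aromatic ring therefore brings no gain over cyclohexyl at this position, while the true size of the step remains unknown.

Open, on these data alone, is whether a plain phenyl or a longer chain such as dodecyl on this oxygen would read as a number in this assay. Also open, as far as these compounds go, is how an amine in place of this oxygen would read.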